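The compounds below may be only part of what the source reports. "The series", "measured", "known", "first", "only" and "open" are said of these compounds alone.

In a functional assay on A549 cells (Homo sapiens) for inhibition, read by CCK-8 assay, with a stated time of 72 h, tested at 10 uM (on this read-out higher numbers stand for more inhibition of growth at the one concentration tested and lower numbers for less inhibition of growth), compound 1 `CN(C)C(=O)c1cc2cnc(Nc3ccc(NC(=O)C4(C(=O)Nc5ccc(F)cc5)CC4)cc3)nc2n1C1CCCC1`, with 4-fluorophenyl on an amide-type nitrogen, gives 102%. Compound 2 `COC(=O)c1cccc(NC(=O)C2(C(=O)Nc3ccc(Nc4ncc5cc(C(=O)N(C)C)n(C6CCCC6)c5n4)cc3)CC2)c1` gives 91%, and compound 3 `CN(C)C(=O)c1cc2cnc(Nc3ccc(NC(=O)C4(C(=O)Nc5cccc(C(F)(F)F)c5)CC4)cc3)nc2n1C1CCCC1` gives 89.2%. Compound 3 therefore stands level with compound 2, as a number 1.8 percentage points lower from compound 2 to compound 3 (within the scatter) shows, and both sit under compound 1.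

Compound 4 `CN(C)C(=O)c1cc2cnc(Nc3ccc(NC(=O)C4(C(=O)Nc5ccc(O)cc5)CC4)cc3)nc2n1C1CCCC1` has 4-hydroxyphenyl in place of the 3-(trifluoromethyl)phenyl of compound 3, on an amide-type nitrogen whose other neighbours are: carbonyl carbon (4-hydroxyphenyl in place of 3-(trifluoromethyl)phenyl on an amide-type nitrogen). Three measured steps change this same group. The a number 12.8 percentage points lower from compound 1 to compound 3 (beyond the scatter) and a number 11 percentage points lower from compound 1 to compound 2 (beyond the scatter) are both modest, and a number 1.8 percentage points lower from compound 2 to compound 3 (within the scatter) is not distinguishable from scatter. Among the compounds with values here, none of the measured compounds carries a hydroxy group, so these steps offer only a rough guide to size.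

With that caution, no change beyond the scatter is expected in this assay, and the expected a number 0.8 percentage points higher from compound 3 to compound 4 (within the scatter) is small. For compound 4 the estimated value is 90%, with an expected range of 74% to 103%.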

Compound 4, percent growth inhibition at one concentration: 94.4%
Estimate against measurement, compound 4: 4.4 percentage points below; the range from low to high includes it.
By their numbers in this assay, from the lowest: compounds 3, 2, 4 and 1 (each within the scatter of the next, the first and the last beyond it).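

In this assay, within the data shown here, the 4-hydroxyphenyl group on the amide-type nitrogen is the first group here to bring a hydrogen-bond donor to this position, and the read-out stays level with the two 3-substituted phenyl compounds: a number 5.2 percentage points higher from compound 3 to compound 4 (within the scatter) and a number 3.4 percentage points higher from compound 2 to compound 4 (within the scatter). Unlike the two earlier replacements of 4-fluorophenyl, which moved the number beyond the scatter, hydroxy in place of fluoro on the aromatic carbon does not, with a number 7.6 percentage points lower from compound 1 to compound 4 (within the scatter). Nothing measured here accounts for these steps.

As far as these compounds go, whether an amine or a carboxylic acid on this phenyl ring would also stay level remains open. So does whether 3-hydroxyphenyl would match 4-hydroxyphenyl, and how these compounds would compare at lower concentrations.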